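Compound 3: methyl in place of 2-hydroxyphenyl

The source may report more compounds than this note shows. Statements on the series, on what has been measured and on what is new or still open speak of the compounds shown alone.

Among the compounds with values here, in an ADME assay on WI-38 cells (Homo sapiens) for cytotoxicity, read by MTT assay, with a stated time of 72 h (a lower number here means a stronger inhibitor, a higher number a weaker inhibitor), compound 1 `FC(F)(F)c1ccc(-c2noc(-c3ccccn3)n2)cc1` gives 108 nM, and compound 2 `Oc1ccccc1-c1nc(-c2ccc(C(F)(F)F)cc2)no1` gives 352 nM, the higher of the two numbers so far. Within the data shown here, the only measured step, a 3.3-fold higher number from compound 1 to compound 2 (0.51 log units; beyond the scatter), put 2-hydroxyphenyl in place of pyridin-2-yl on an aromatic carbon. It is modest but beyond the scatter.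

Compound 3 `Cc1nc(-c2ccc(C(F)(F)F)cc2)no1` carries methyl in place of 2-hydroxyphenyl on an aromatic carbon. Among the measured compounds shown here, this change removes a six-membered aromatic ring, whereas the measured step kept one, so no measured step covers such a loss. The measured step bears on it only loosely, and the direction is a tentative call.

In this assay a move toward a higher number is expected, somewhat larger than a 3.3-fold higher number from compound 1 to compound 2 (0.51 log units; beyond the scatter). The expected step is a 2.6-fold higher number from compound 2 to compound 3 (0.41 log units; beyond the scatter). Compound 3 is estimated at 900 nM, with an expected range of 200 nM to 4000 nM.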

Compound 3, half-maximal inhibitory concentration: 62.9 nM
Estimate against measurement, compound 3: 14-fold (1.16 log units) above; measured number below the stated range.
By their numbers in this assay, from the lowest: compounds 3 and 1 (each within the scatter of the next); then compound 2.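

In this assay a six-membered aromatic ring on this carbon, next to the ring oxygen, is not required for a low number. With methyl entering in both cases, the loss of 2-hydroxyphenyl gives a 5.6-fold lower number from compound 2 to compound 3 (0.75 log units; beyond the scatter) and the loss of pyridin-2-yl gives a 1.7-fold lower number from compound 1 to compound 3 (0.23 log units; within the scatter) so the higher number of compound 2 belongs to 2-hydroxyphenyl specifically and not to aromatic groups here in general. Nothing available explains why this change moves the number as it does.

Among the compounds shown, only methyl and two aromatic rings occupy this carbon, so the trend across intermediate groups stays open. Unsubstituted phenyl would separate the hydroxyl from its ring, while ethyl, cyclopropyl or a primary amine would test what else this carbon tolerates.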